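The compounds below may be only part of what the source reports. "The series", "measured", "known", "first", "only" and "open" are said of these compounds alone.

Measured in an ADME assay on microsomes from liver (Rattus norvegicus) for metabolic stability; a higher number here means faster removal of the compound, a lower number slower removal:
- Compound 1 `CC(C)Oc1cc(Oc2ccc(S(C)(=O)=O)cc2)cc(-c2cncc(=O)[nH]2)c1`: 61 mL/min/kg
- Compound 2 `CCS(=O)(=O)c1ccc(Oc2cc(O[C@@H](C)CO)cc(-c3nccc(=O)[nH]3)c2)cc1`: < 25.4 mL/min/kg (a limit, not a number)

Within the data shown here, compound 1 holds the only exact number so far, so it is the natural starting point. Compound 3 `CCc1cnc(-c2cc(Oc3ccc(S(C)(=O)=O)cc3)cc(OC(C)C)c2)[nH]c1=O` keeps the rest of compound 1 but exchanges the group on an aromatic carbon of a six-membered aromatic ring of carbon only, meta to a large group and meta to an isopropoxy group: a group of 9 heavy atoms (6 carbon, 2 nitrogen, 1 oxygen; one six-membered aromatic ring with 2 hetero atoms) in place of a group of 7 heavy atoms (4 carbon, 2 nitrogen, 1 oxygen; one six-membered aromatic ring with 2 hetero atoms), on an aromatic carbon. Among the measured compounds shown here, no measured step covers this exchange, so only a small upward move is expected, and the expected step is a 1.1-fold higher number from compound 1 to compound 3 (0.06 log units; within the scatter). For compound 3 the estimate is 70 mL/min/kg, within a range of 35 mL/min/kg to 130 mL/min/kg.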

Compound 3, clearance: 171 mL/min/kg
Beside the measured number, compound 3's estimate is 2.4-fold (0.39 log units) below it, and the stated range ends below it.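

In this assay, putting the group of 9 heavy atoms in place of the group of 7 heavy atoms on this aromatic carbon gives a 2.8-fold higher number from compound 1 to compound 3 (0.45 log units; beyond the scatter) and so shows that the number responds to a change at this place. The earlier compounds shown here could not show this, as they differ in more than one place. Nothing measured here explains the rise.

From the compounds shown here alone, it remains open whether a group carrying an amine or a longer chain at this place would raise or lower the number. Going by these compounds, it is also open whether the same exchange would have a similar effect with another group in place of the isopropoxy group.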